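The source may hold more compounds than are shown below. What is called first, only, known or untested is meant among the compounds shown, and "the series" means these compounds.

Measured so far:
- Compound 1, `Cn1cc(-c2ccc3nnc(Sc4ccc5ncc(N6CCC(N)C6)cc5c4)n3c2)cn1`, gives in an ADME assay on cytosol from liver for pharmacokinetics, with aldehyde oxidase 1 (Macaca fascicularis) as the target, read by LC-MS, with a stated time of 120 min, tested at 1 uM (a lower number here means that the compound disappears faster, a higher number that the compound lasts longer), a reading of > 8.33 h, which is a limit of the assay and not a number.
- Compound 2, `Cn1cc(-c2ccc3nnc(Sc4ccc5ncc(NCC6CCOC6)cc5c4)n3c2)cn1`, gives in this assay a half-life of 2.4 h.

Both compounds share one core and differ only in the group attached to a nitrogen on an aromatic ring. Among the compounds with values here, compound 2 holds the only true number in this assay; the other reading is a limit, (the limit of > 8.33 h in this assay, at which 1 of the 2 values shown sits). Within the data shown here, the single measured step, an at least 3.4-fold lower number from compound 1 to compound 2 (0.54 log units; beyond the scatter), shows that exchanging the group at this site can move the half-life beyond the scatter, although the limit leaves the full size of that move open.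

Compound 3, `Cn1cc(-c2ccc3nnc(Sc4ccc5ncc(NCCO)cc5c4)n3c2)cn1`, is not yet measured. It differs from compound 2 as follows: hydroxymethyl in place of oxolan-3-yl on a saturated chain carbon bound to a nitrogen on an aromatic ring. Among the measured compounds shown here, the measured step concerns a different exchange at the same site and so offers only loose guidance; no measured step trims a ring down to a short hydroxylated chain. The step expected here is no change at the digits printed from compound 2 to compound 3 (within the scatter), within the usual scatter. Compound 3 is therefore estimated at 2.4 h, with a likely range from 1 h to 6 h.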

Compound 3, half-life: 0.152 h
Compound 3: the middle estimate sits 16-fold (1.20 log units) above what was measured, outside the stated range (below it).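

Exchanging oxolan-3-yl for hydroxymethyl on the saturated chain carbon bound to a nitrogen on an aromatic ring gives, in this assay, a 16-fold lower number from compound 2 to compound 3 (1.20 log units; beyond the scatter). This shows that the half-life responds strongly to a change at this site even when the amine linkage and the shared core stay the same and the entering group still holds an oxygen, and the span across the site now reaches an at least 54-fold lower number from compound 1 to compound 3 (1.73 log units; beyond the scatter). The reading of compound 1 in that span is a limit of the assay, so the full size of the step stays open: the limit of > 8.33 h in this assay, at which 1 of the 3 values shown sits.

The exchange from compound 2 to compound 3 removes the ring, shortens the group and brings in a hydrogen-bond donor all at once, and the compounds shown do not separate these changes or give their cause. A 2-methoxyethyl group, which has a short chain without the hydroxyl hydrogen, and a 3-hydroxypropyl group, which has a longer chain ending in a hydroxyl, are among the groups that could begin to pull them apart.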